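Swapping the Amide Substituent of Compound 2

The source may report more compounds than this note shows. Statements on the series, on what has been measured and on what is new or still open speak of the compounds shown alone.

Measured compounds:
compound 1, `O=c1cc(-c2ccccc2)[nH]c(=O)n1O`: 630 nM
compound 2, `CNC(=O)c1nc(-c2cccs2)[nH]c(=O)c1O`: 12000 nM

In an assay on isolated protein for inhibition of Flap endonuclease 1 (Homo sapiens) (on this read-out higher numbers stand for weaker inhibition and lower numbers for stronger inhibition), compound 1 gives 630 nM, while compound 2 gives 12000 nM. Compound 2 therefore stands at the higher of the two numbers, and its nearest neighbour, compound 1, sits well beyond the scatter below it; the two share no single-point change, so their values are simply reported side by side. Compound 3, `O=C(Nc1ccc(F)cc1)c1nc(-c2cccs2)[nH]c(=O)c1O`, has yet to be measured in this assay. It differs from compound 2 in one place: 4-fluorophenyl in place of methyl on an amide-type nitrogen. Going by the values given here, no step between measured compounds matches this change, so the expectation rests on compound 2 at 12000 nM and on the nature of the change itself, a move from a small alkyl group to an aromatic one on the amide nitrogen. Compound 3 is expected to reach a lower number than compound 2, by a 4.8-fold lower number from compound 2 to compound 3 (0.68 log units; beyond the scatter), a step beyond the scatter though smaller than the gap separating compound 2 from compound 1. For compound 3 the estimate is 2500 nM, with a range from 500 nM to 12000 nM.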

Compound 3, half-maximal inhibitory concentration: 10500 nM
Estimate against measurement, compound 3: 4.2-fold (0.62 log units) below; the measured number falls inside the stated range.
By their numbers in this assay, from the lowest: compound 1; then compounds 3 and 2 (each within the scatter of the next).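

In this assay the amide nitrogen gets its first single-point comparison, where 4-fluorophenyl in place of methyl gives a 1.1-fold lower number from compound 2 to compound 3 (0.06 log units; within the scatter) on this read-out. Going from the 1 heavy atom of methyl to the 7 heavy atoms of 4-fluorophenyl, with its six-membered aromatic ring, therefore leaves compound 2 and compound 3 indistinguishable, and neither a gain nor a loss can be assigned to this change. Nothing available here bears on why the two compounds read alike.

Going by these compounds, what a plain phenyl, a benzyl or a longer alkyl chain would give on this same amide nitrogen remains open, as does whether the fluorine plays any part in the value of compound 3. Also open, on these data alone, is whether an amine or a carboxylic acid carried on the aromatic ring would move the number beyond the scatter, and whether this swap would read the same way on a different core.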